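Thiazole in place of dimethylfuran on the alkyne arm

A few compounds are considered here, and "the series" means these few. Any claim that something is new, unique, unknown or untested is made for them only; others in the source may bear on it.

Compound 2 `CNC(=O)[C@@]12C[C@@H]1[C@@H](n1cnc3c(NC)nc(C#Cc4cc(C)c(C)o4)nc31)[C@H](O)[C@@H]2O` is measured in an assay on CHO cells for displacement of a labelled ligand from adenosine receptor A3 (Homo sapiens), read by scintillation counting, with a stated time of 60 min (on this read-out lower numbers stand for stronger inhibition and higher numbers for weaker inhibition), at 1.45 nM. For the measured compounds named here, its only comparison is compound 1 `CNC(=O)[C@@]12C[C@@H]1[C@@H](n1cnc3c(NC)nc(C#Cc4ncccn4)nc31)[C@H](O)[C@@H]2O`, which in this assay gives 1.97 nM; the step of a 1.4-fold lower number from compound 1 to compound 2 (0.13 log units; within the scatter) leaves the two within the scatter of each other. Compound 3 `CNC(=O)[C@@]12C[C@@H]1[C@@H](n1cnc3c(NC)nc(C#Cc4nccs4)nc31)[C@H](O)[C@@H]2O` carries the change (1,3-thiazol-2-yl in place of 4,5-dimethylfuran-2-yl on a triple-bonded carbon). Going by the values given here, the single relevant step, a heteroaryl swap on the same triple-bonded carbon, produced no shift beyond the scatter, so a comparable swap is expected to give little movement in this assay. Compound 3 is therefore estimated at 1.8 nM, between 0.8 nM and 4 nM, a step of a 1.2-fold higher number from compound 2 to compound 3 (0.09 log units; within the scatter).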

Compound 3, inhibition constant: 2.1 nM
The estimate for compound 3 lay 1.2-fold (0.07 log units) below the measured number, within the range that was stated.
By their numbers in this assay, from the lowest: compounds 2, 1 and 3 (each within the scatter of the next).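

In this assay, a third heteroaryl group on the triple-bonded carbon again gives no shift beyond the scatter: a 1.4-fold higher number from compound 2 to compound 3 (0.16 log units; within the scatter), and a 1.1-fold higher number from compound 1 to compound 3 (0.03 log units; within the scatter). All three steps among these compounds now lie within the scatter, although 1,3-thiazol-2-yl has fewer heavy atoms than 4,5-dimethylfuran-2-yl and a second hetero atom in its five-membered ring. Nothing available explains why these groups give such similar numbers. Going by these compounds, whether an amine, a carboxylic acid or a longer alkyl chain on the triple-bonded carbon would stay within the scatter of these three remains open.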